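The compounds below may be only part of what the source reports. "The series", "measured", "known", "first", "only" and "open" are said of these compounds alone.

Compound 1, `COc1nc(N)nc2c1c(-c1cc3ccccc3o1)cn2[C@@H]1O[C@H](CO)[C@@H](O)[C@H]1O`, gives 15500 nM in a functional assay on K562 cells (Homo sapiens), read by MTT assay, with a stated time of 72 h; a lower number here means a stronger inhibitor, a higher number a weaker inhibitor. Among the two numbers found in this assay, compound 1 holds the higher one, and its nearest neighbour is compound 3, `COc1ncnc2c1c(-c1cc3ccccc3o1)cn2[C@@H]1O[C@H](CO)[C@@H](O)[C@H]1O`, which gives 13100 nM. For the measured compounds named here, the step of a 1.2-fold lower number from compound 1 to compound 3 (0.07 log units; within the scatter) is the only single-point change measured, and it does not reach beyond the scatter. Compound 2, `O=c1[nH]cnc2c1c(-c1ccsc1)cn2[C@@H]1O[C@H](CO)[C@@H](O)[C@H]1O`, reaches only a limit of this assay, > 20000 nM. That limit, (the limit of > 20000 nM in this assay, at which 1 of the 3 values shown sits), is one at which one of the three values recorded in this assay sits.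

Compound 4, `COc1nc(N)nc2c1c(-c1ccco1)cn2[C@@H]1O[C@H](CO)[C@@H](O)[C@H]1O`, follows from compound 1 by the change (furan-2-yl in place of 1-benzofuran-2-yl on an aromatic carbon). Going by the values given here, no measured step touches the aryl group on the five-membered ring of the shared core; the one step available, from amino to hydrogen on the six-membered ring, lies within the scatter and gives no guide to a change at this other position. With nothing in the data pointing in either direction, the expectation for compound 4 is a number near that of compound 1, with a step of a 1.3-fold higher number from compound 1 to compound 4 (0.11 log units; within the scatter) that is not expected to exceed the scatter, and a fair chance that only a limit is reported. Compound 4 is therefore estimated at 20000 nM, within a range of 8000 nM to 50000 nM.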

Compound 4, half-maximal inhibitory concentration: > 20000 nM
Compound 4: no number, only a limit; the forecaster's own chance of this, stated with the estimate: 45%; the middle value sits exactly at the limit.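

In this assay, furan-2-yl in place of 1-benzofuran-2-yl gives an at least 1.2-fold higher number from compound 1 to compound 4 (0.11 log units; that floor lies within the scatter), the only step shown at this aromatic carbon of the five-membered aromatic ring. Compound 4 carries a limit of the assay and not a number: > 20000 nM. The step therefore shows that giving up the six-membered aromatic ring of carbon only brings no gain here, while its size remains unknown and its floor establishes no loss beyond the scatter, and the limit now recurs in the series: the limit of > 20000 nM in this assay, at which 2 of the 4 values shown sit.

From the compounds shown here alone, how far compound 4 really lies from compound 1 stays open, and so does whether the amino group on the six-membered ring matters at all once furan-2-yl is in place. Also open, going by these compounds, is whether a larger aromatic group such as naphthalen-2-yl, or a 1-benzofuran-2-yl carrying an amine or a carboxylic acid, would give a lower number at this position than the 1-benzofuran-2-yl of compound 1.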